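Hydroxy for ureido on the double-bonded nitrogen

A few compounds are considered here, and "the series" means these few. Any claim that something is new, unique, unknown or untested is made for them only; others in the source may bear on it.

Measured so far in a functional assay on HCT-116 cells (Homo sapiens) for inhibition, read by sulforhodamine B assay, with a stated time of 48 h; a higher number here means a weaker inhibitor, a lower number a stronger inhibitor:
- compound 1 `COc1cc2c(cc1CC=C(C)C)/C(=N/NC(N)=O)C[C@@H](c1ccc(O)cc1)O2`, compound 1 gives 24300 nM
- compound 2 `COc1ccc([C@@H]2C/C(=N/OCc3cn(-c4ccccc4CO)nn3)c3cc(CC=C(C)C)c(OC)cc3O2)cc1`, compound 2 gives 29900 nM

Compound 1 has the lower of the two numbers in this assay, but the gap to compound 2 lies within the scatter, so the two are not separable on these data. Both stand at the weak end of what this assay resolves.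

The next compound is compound 3 `COc1cc2c(cc1CC=C(C)C)/C(=N/O)C[C@@H](c1ccc(O)cc1)O2`, not yet measured in this assay. It keeps the core of compound 1 and changes one place: hydroxy in place of ureido on a double-bonded nitrogen. Among the measured compounds shown here, no step between measured compounds informs this change, so the expectation rests on compound 1 alone.

With the series sitting flat at weak inhibition, the step of a 1.0-fold higher number from compound 1 to compound 3 (0.01 log units; within the scatter) is expected to be none beyond the scatter. Compound 3 is expected near 25000 nM, with a range from 8000 nM to 80000 nM.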

Compound 3, half-maximal inhibitory concentration: 29700 nM
Compound 3: middle estimate off by 1.2-fold (0.07 log units), on the low side; low and high end bracket the measured number.
By their numbers in this assay, from the lowest: compounds 1, 3 and 2 (each within the scatter of the next).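

Among the compounds shown here, on a double-bonded nitrogen, hydroxy in place of ureido gives a 1.2-fold higher number from compound 1 to compound 3 (0.09 log units; within the scatter) in this assay, the first step that isolates this position. Ureido, with its 4 heavy atoms, and hydroxy, with 1, cannot be told apart here, so the ureido group is not needed to hold inhibition at this weak level, and cutting it back to hydroxy brings no gain. No measurement in hand bears on why the two groups read alike.

On these data alone, it remains open whether any other group on this nitrogen, such as a short chain ending in a carboxylic acid or an amine, would move the number beyond the scatter. As far as these compounds go, it is also open whether this insensitivity holds when the rest of the core of compound 1 is changed.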